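Isobutyl to Cyclohexyl on the Amide-Side Chain

This account rests on a few compounds, and the source may have more. Where it says the series, first, only, none or still open, it means among the compounds named here.

Compound 1 `Cc1cc(CNC(=O)c2cc3nc(C)c([C@H](OC(C)(C)C)C(=O)O)c(-c4cc(F)c5c(c4C)CCCO5)n3n2)ccc1F` carries a 4-fluoro-3-methylphenyl group on a saturated chain carbon bound to an amide-type nitrogen. In an ADME assay on MT2 cells (Homo sapiens) for cytotoxicity (a lower number here means that less compound is tolerated, a higher number that more compound is tolerated), compound 1 gives only a limit, > 40000 nM. Compound 2 `Cc1nc2cc(C(=O)NCCC(C)C)nn2c(-c2cc(F)c3c(c2C)CCCO3)c1[C@H](OC(C)(C)C)C(=O)O` has isobutyl at that place. In this assay compound 2 again gives only a limit, > 40000 nM. The step that the two limits leave unreadable from compound 1 to compound 2 cannot be read, since both values sit at the limit of > 40000 nM in this assay, at which 2 of the 2 values shown sit. Compound 3 `Cc1nc2cc(C(=O)NCC3CCCCC3)nn2c(-c2cc(F)c3c(c2C)CCCO3)c1[C@H](OC(C)(C)C)C(=O)O` differs from compound 2 by cyclohexyl in place of isobutyl on a saturated chain carbon bound to an amide-type nitrogen. Within the data shown here, no measured step bears on this exchange. For compound 3 no change beyond the scatter is expected, with an estimate of 45000 nM (range 20000 nM to 100000 nM), a step that the limit leaves unreadable from compound 2 to compound 3.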

Compound 3, half-maximal cytotoxic concentration: > 40000 nM
Compound 3: only a limit was reported; the forecaster's own chance of this, stated with the estimate: 80%; the middle value lies beyond the limit too.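

No step can be read among compound 1, compound 2 and compound 3 in this assay, because each gives only a limit: the limit of > 40000 nM in this assay, at which 3 of the 3 values shown sit. The compounds shown leave open how far these amide-side groups differ in tolerated concentration, and whether any such group gives a readable number.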